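Replacing a sulfur link with oxygen on the fluorophenyl arm

This account rests on a few compounds, and the source may have more. Where it says the series, first, only, none or still open, it means among the compounds named here.

The shared core of this series is shown by compound 1 `CN(C)C(=O)n1cc(C(=O)c2ccn3c2CSC3c2cccnc2)c2ccccc21`. In a functional assay (Oryctolagus cuniculus) for antagonist activity at platelet-activating factor receptor (Cavia porcellus) (on this read-out lower numbers stand for stronger inhibition and higher numbers for weaker inhibition), compound 1 gives 95 nM. Compound 2 `CN(C)C(=O)n1cc(C(=O)c2ccn3c2CSC3c2cccnc2)c2ccc(Sc3ccc(F)cc3)cc21` carries a (4-fluorophenyl)sulfanyl group in place of a hydrogen on an aromatic carbon, and in this assay compound 2 gives 17 nM. That single change brought a 5.6-fold lower number from compound 1 to compound 2 (0.75 log units; beyond the scatter). Among the measured compounds shown here, of the two numbers measured so far, compound 2 stands lowest, with compound 1 the nearest at a higher value.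

Compound 3 `CN(C)C(=O)n1cc(C(=O)c2ccn3c2CSC3c2cccnc2)c2ccc(Oc3ccc(F)cc3)cc21` differs from compound 2 in one place: 4-fluorophenoxy in place of (4-fluorophenyl)sulfanyl on an aromatic carbon. For the measured compounds named here, no measured step covers a change of the atom that joins the fluorophenyl ring to the core; the only step at hand, from compound 1 to compound 2, concerns adding the whole group and tells nothing about its bridging atom. The expectation is therefore a small move, within or close to the scatter, written as a 1.5-fold higher number from compound 2 to compound 3 (0.17 log units; within the scatter). For compound 3 in this assay the estimated value is 25 nM, with a likely range from 8 nM to 80 nM.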

Compound 3, inhibition constant: 1.7 nM
Beside the measured number, compound 3's estimate is 15-fold (1.17 log units) above it; measured number below the stated range.
By their numbers in this assay, from the lowest: compound 3; then compound 2; then compound 1.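

In this assay, the single atom that joins the fluorophenyl ring to the shared core turns out to matter a great deal: oxygen in place of sulfur gives a 10-fold lower number from compound 2 to compound 3 (1.00 log units; beyond the scatter), although the leaving and entering groups have the same count of heavy atoms, hydrogen-bond donors and hydrogen-bond acceptors and carry the same aromatic ring. The benefit of adding this arm to the core therefore depends on its linking atom and not on the fluorophenyl ring alone, as the oxygen-linked arm gives a 56-fold lower number from compound 1 to compound 3 (1.75 log units; beyond the scatter) while the sulfur-linked arm gives the smaller 5.6-fold lower number from compound 1 to compound 2 (0.75 log units; beyond the scatter). Nothing at hand explains why the oxygen link gives the lower number.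

The compounds shown leave open whether a methylene or an amine as the link would match the oxygen, or whether oxygen is special among such links. They also leave open what the fluorine contributes, which a plain phenoxy group, or a phenoxy group with chlorine or methoxy in its place, could show.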